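Inverting the stereocentre in the trifluoromethyl series

The source may hold more compounds than are shown below. What is called first, only, known or untested is meant among the compounds shown, and "the series" means these compounds.

In an ADME assay on microsomes from liver (Rattus norvegicus) for metabolic stability, read by LC-MS, using NADPH, with stated times of 6 min and 10 min, tested at 0.5 uM (on this read-out lower numbers stand for a less stable compound and higher numbers for a more stable compound), compound 1 (`CC(=O)N1C[C@@H](C)N(c2cc(-c3cc(Cl)c4c(N)ncnn34)ccc2C#N)C(=O)C1(C)C`) gives 59% and compound 2 (`CC(=O)N1C[C@H](C)N(c2cc(-c3cc(Cl)c4c(N)ncnn34)ccc2C#N)C(=O)C1(C)C`) gives 94%. Going by the values given here, compound 3 (`CC(=O)N1C[C@@H](C)N(c2cc(-c3cc(C(F)(F)F)c4c(N)ncnn34)ccc2C#N)C(=O)C1(C)C`) gives 43%, the lowest of the three numbers so far. Its link to the rest of the series is a number 16 percentage points lower from compound 1 to compound 3 (beyond the scatter), a modest step with trifluoromethyl in place of chloro on an aromatic carbon.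

Compound 4 (`CC(=O)N1C[C@H](C)N(c2cc(-c3cc(C(F)(F)F)c4c(N)ncnn34)ccc2C#N)C(=O)C1(C)C`) has not yet been measured. Its relation to compound 3 is simple: the two compounds have the same atoms and bonds and differ only in configuration as drawn: 1 of 1 stereo elements differ; a stereocentre at a saturated ring carbon is drawn R in compound 3 and S in compound 4.

Among the compounds with values here, the closest precedent is the same kind of inversion in the chloro pair, which gives a number 35 percentage points higher from compound 1 to compound 2 (beyond the scatter). That large step stands with the fact that compounds 1 and 2 differ only in the configuration as drawn. The trifluoromethyl step bears less directly, since it shows only that the starting point here is lower and leaves configuration unchanged. The inversion is therefore expected to raise the number by a large amount again, though this rests on a single pair, and the read-out has limited room at the top.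

The estimated step is a number 33 percentage points higher from compound 3 to compound 4 (beyond the scatter), upward and large. The expected value for compound 4 is 76%, within an estimated range from 60% to 92%.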

Compound 4, percent of the compound remaining: 91%
The estimate for compound 4 lay 15 percentage points below the measured number; the measured number falls inside the stated range.
By their numbers in this assay, from the lowest: compound 3; then compound 1; then compounds 4 and 2 (each within the scatter of the next).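

In this assay, inversion of the stereocentre at the saturated ring carbon raises the number in both the chloro and the trifluoromethyl pairs, with a number 35 percentage points higher from compound 1 to compound 2 (beyond the scatter) and now a number 48 percentage points higher from compound 3 to compound 4 (beyond the scatter), and neither pair goes against this direction. The change in compound 4 can be placed on this stereocentre alone: the fact that compounds 3 and 4 differ only in the configuration as drawn. With the stereocentre drawn S, trifluoromethyl in place of chloro on the aromatic carbon gives a number 3 percentage points lower from compound 2 to compound 4 (within the scatter), and the lower number seen for this change with the stereocentre drawn R is not shown to depend on configuration: the same change on two cores in this assay, a number 16 percentage points lower (beyond the scatter) from compound 1 to compound 3 and a number 3 percentage points lower (within the scatter) from compound 2 to compound 4, 13 percentage points apart, within the scatter of two such steps.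

As far as these compounds go, the four compounds cover only chloro and trifluoromethyl on the aromatic carbon and only methyl at the stereocentre, so it remains open whether a bromo or methoxy group at the former, or an ethyl group at the latter, would follow the same pattern. The two pairs also cannot show whether the preference for the S drawing holds with the acetyl group on the ring nitrogen replaced by a longer acyl chain.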